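From isopropyl to thiophen-2-yl on a sulfur-bound carbon

The compounds below may be only part of what the source reports. "The series", "measured", "known", "first", "only" and "open" are said of these compounds alone.

- compound 1 `CC[S+]([O-])CCCCN=C=S`: 9810 nM
- compound 2 `CCCC[S+]([O-])CCCCN=C=S`: 6470 nM
- compound 3 `CC(C)C[S+]([O-])CCCCN=C=S`: 5700 nM

In a functional assay on SH-SY5Y cells (Homo sapiens) for cytotoxicity, read by MTT assay, with a stated time of 72 h (on this read-out lower numbers stand for stronger inhibition and higher numbers for weaker inhibition), compound 3 gives 5700 nM, a value that cannot be told apart from those of compound 1 and compound 2. The next structure, compound 4 `[O-][S+](CCCCN=C=S)Cc1cccs1`, carries thiophen-2-yl in place of isopropyl on a saturated chain carbon bound to a sulfur.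

Three measured steps offer guidance: a 1.5-fold lower number from compound 1 to compound 2 (0.18 log units; within the scatter), a 1.7-fold lower number from compound 1 to compound 3 (0.24 log units; within the scatter) and a 1.1-fold lower number from compound 2 to compound 3 (0.06 log units; within the scatter). All of them are small and lie within the scatter, so reshaping the open chain has shown no clear effect in this assay. Within the data shown here, no measured compound carries a ring, which leaves this particular swap untested and the forecast uncertain.

The expected step is a 1.1-fold lower number from compound 3 to compound 4 (0.06 log units; within the scatter), which would not stand out from the scatter. For compound 4 the estimated value is 5000 nM, with an expected range of 2200 nM to 10000 nM.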

Compound 4, half-maximal inhibitory concentration: 5310 nM
Compound 4: the middle estimate sits 1.1-fold (0.03 log units) below what was measured; the measured number falls inside the stated range.
By their numbers in this assay, from the lowest: compounds 4, 3, 2 and 1 (each within the scatter of the next).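

Compound 4 brings the first ring to this place, and in this assay the steps of a 1.1-fold lower number from compound 3 to compound 4 (0.03 log units; within the scatter) and a 1.2-fold lower number from compound 2 to compound 4 (0.09 log units; within the scatter) and a 1.8-fold lower number from compound 1 to compound 4 (0.27 log units; within the scatter) all lie within the scatter. The earlier compounds shown here varied only open chains, whereas this result shows that thiophen-2-yl, a five-membered aromatic ring with a hetero atom, on a saturated chain carbon bound to a sulfur gives a number that cannot be told apart from those of the open-chain compounds. Nothing available here bears on why the swap of an open chain for this ring leaves the numbers indistinguishable.

From the compounds shown here alone, a single ring is a narrow sample, so it remains open whether a phenyl ring would also stay within the scatter. Going by these compounds, it also remains open whether a chain ending in an amine or a carboxylic acid, placed on the same carbon, would give a clearly different number.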